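Swapping benzyl for an indole amide on compound 1

The source may report more compounds than this note shows. Statements on the series, on what has been measured and on what is new or still open speak of the compounds shown alone.

Within the data shown here, in an assay on membranes from Cortex for displacement of a labelled ligand from Sigma non-opioid intracellular receptor 1 (Cavia porcellus), read by scintillation counting, with a stated time of 120 min (on this read-out higher numbers stand for weaker inhibition and lower numbers for stronger inhibition), compound 1 `Fc1ccc(C(SCCNC2CCN(Cc3ccccc3)CC2)c2ccc(F)cc2)cc1` gives 3.81 nM, the lower of the two numbers measured so far. Compound 2 `OC(Cc1ccccc1)CN1CCC(NCCSC(c2ccc(F)cc2)c2ccc(F)cc2)CC1` gives 309 nM, and the step of an 81-fold higher number from compound 1 to compound 2 (1.91 log units; beyond the scatter) shows how costly a single change can be. Compound 3 `O=C(c1cc2ccccc2[nH]1)N1CCC(NCCSC(c2ccc(F)cc2)c2ccc(F)cc2)CC1` differs from compound 1 thus: (1H-indol-2-yl)carbonyl in place of benzyl on an amine nitrogen in a ring. Among the measured compounds shown here, the one measured step concerns a different change, so it offers only loose guidance. Weaker binding is nonetheless expected: the step of a 16-fold higher number from compound 1 to compound 3 (1.20 log units; beyond the scatter) is the estimated outcome. Compound 3 is estimated at 60 nM, with a range from 8 nM to 500 nM.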

Compound 3, inhibition constant: 1130 nM
For compound 3 the middle estimate is 19-fold (1.27 log units) below the measured one; measured number outside the range, above it.
By their numbers in this assay, from the lowest: compound 1; then compound 2; then compound 3.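

This position tolerates the change poorly: putting (1H-indol-2-yl)carbonyl in place of benzyl on the amine nitrogen in the ring brings a 300-fold higher number from compound 1 to compound 3 (2.47 log units; beyond the scatter). The new group also falls short of the 2-hydroxy-3-phenylpropyl group, with a 3.7-fold higher number from compound 2 to compound 3 (0.56 log units; beyond the scatter), so neither replacement of benzyl shown here keeps its low number. Nothing measured here gives a reason for this loss.

As far as these compounds go, the carbonyl and the indole ring enter together, so it remains open which of them carries the loss. A plain benzoyl group, or an indol-2-ylmethyl group with a saturated carbon in place of the carbonyl, would separate the two.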